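Amine side chain change from compound 2 to compound 3

A few compounds are considered here, and "the series" means these few. Any claim that something is new, unique, unknown or untested is made for them only; others in the source may bear on it.

Compound 1 (`CCNCCC(=O)Nc1cccc2c1CN(C)CC2c1ccccc1`): > 160 mg/kg (a limit)
Compound 2 (`CC(C)NCCC(=O)Nc1cccc2c1CN(C)CC2c1ccccc1`): about 125 mg/kg

For the measured compounds named here, in a functional assay on the whole organism for inhibition, with Mus musculus as the target (on this read-out higher numbers stand for an effect only at larger amounts of compound and lower numbers for an effect already at smaller amounts), compound 2 gives about 125 mg/kg, the only actual number so far. Compound 1 gives > 160 mg/kg, which is a limit of the assay.

Compound 3 (`CN1Cc2c(NC(=O)CN3CCCC3)cccc2C(c2ccccc2)C1`) has pyrrolidin-1-yl in place of (isopropylamino)methyl on a saturated chain carbon bound to a carbonyl carbon. Going by the values given here, no measured step covers this exchange. Among the compounds with values here, the nearest guide is the one measured step, an at least 1.2-fold lower number from compound 1 to compound 2 (0.10 log units; that floor lies within the scatter), so no step beyond the scatter is expected. The estimated change is a 1.0-fold lower number from compound 2 to compound 3 (0.02 log units; within the scatter). For compound 3 the estimated dose is 120 mg/kg, with an expected range from 45 mg/kg to 300 mg/kg.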

Compound 3, dose for half-maximal effect: about 25 mg/kg
Estimate against measurement, compound 3: 4.8-fold (0.68 log units) above; measured number outside the range, below it.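

In this assay, for the compounds shown here, the first step that clearly lies beyond the scatter comes from changing the side chain itself, with pyrrolidin-1-yl entering on the saturated chain carbon bound to a carbonyl carbon: a 5.0-fold lower number from compound 2 to compound 3 (0.70 log units; beyond the scatter). The same exchange measured from the ethylamino side chain gives an at least 6.4-fold lower number from compound 1 to compound 3 (0.80 log units; beyond the scatter). Compound 1 holds a limit of the assay, not a number: the limit of > 160 mg/kg in this assay, at which 1 of the 3 values shown sits.

Going by these compounds, the exchange closes a ring, removes a hydrogen-bond donor and turns 2-(isopropylamino)ethyl into (pyrrolidin-1-yl)methyl all at once, so it remains open which of these carries the step. 2-(Pyrrolidin-1-yl)ethyl would separate ring from chain length, and piperidin-1-yl would test another ring.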